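Swapping trifluoromethyl for methyl in a seizure-protection series

The source may hold more compounds than are shown below. What is called first, only, known or untested is meant among the compounds shown, and "the series" means these compounds.

Three compounds built on one shared core were tested in a functional assay on the whole organism (strain Swiss) with Mus musculus as the target, in the maximal electroshock model, with a stated time of 1 h, at a dose of 100 mg/kg by the intraperitoneal route; a higher number here means a stronger effect of the compound at the dose given, a lower number a weaker effect. Compound 1 `CCC(C(=O)N1CCN(c2cccc(C(F)(F)F)c2)CC1)N1C(=O)CCC1=O` gives 0%, and compound 2 `CCC(C(=O)N1CCN(c2cccc(C)c2)CC1)N1C(=O)CCC1=O` gives 0%. The two differ only in methyl in place of trifluoromethyl on an aromatic carbon, and the step is no change at the digits printed from compound 1 to compound 2 (within the scatter). Compound 3 `CC(C(=O)N1CCN(c2cccc(C(F)(F)F)c2)CC1)N1C(=O)CCC1=O` gives 50%; it differs from compound 1 in hydrogen in place of methyl on a saturated chain carbon, two bonds along the chain from an amide-type nitrogen in a ring and a carbonyl carbon, and the step is a number 50 percentage points higher from compound 1 to compound 3 (beyond the scatter). Compound 3 thus stands highest of the three, its steps to compound 1 and to compound 2 both beyond the scatter.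

Compound 4 `Cc1cccc(N2CCN(C(=O)C(C)N3C(=O)CCC3=O)CC2)c1` has not yet been measured. It differs from compound 3 in methyl in place of trifluoromethyl on an aromatic carbon, the same change as from compound 1 to compound 2; among these compounds it occurs twice in all. The two cores on which it is made differ in hydrogen in place of methyl on a saturated chain carbon, two bonds along the chain from an amide-type nitrogen in a ring and a carbonyl carbon. The earlier step, no change at the digits printed from compound 1 to compound 2 (within the scatter), began from a compound with no effect, so it cannot show whether the change lowers a real effect. The step from compound 3 to compound 4 is therefore expected to be a number 15 percentage points lower from compound 3 to compound 4 (beyond the scatter), resting on that earlier step and on the room compound 3 leaves for a fall. Compound 4 is expected to give about 35%, estimated between 0% and 70%.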

Compound 4, a percentage reported as activity, at one dose (the size of the read-out at that dose, not a potency): 0%
Beside the measured number, compound 4's estimate is 35 percentage points above it, within the range that was stated.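

In this assay, methyl in place of trifluoromethyl brings a number 50 percentage points lower from compound 3 to compound 4 (beyond the scatter), so a change that left no visible mark on the core of compound 1 removes the whole effect on the core of compound 3: the same change on two cores in this assay, no change at the digits printed (within the scatter) from compound 1 to compound 2 and a number 50 percentage points lower (beyond the scatter) from compound 3 to compound 4, 50 percentage points apart, beyond the scatter of two such steps. Hydrogen in place of methyl on the chain carbon does not carry over either, for with methyl on the aromatic ring it brings no change at the digits printed from compound 2 to compound 4 (within the scatter), unlike the rise it gave with trifluoromethyl there: the same change on two cores in this assay, a number 50 percentage points higher (beyond the scatter) from compound 1 to compound 3 and no change at the digits printed (within the scatter) from compound 2 to compound 4, 50 percentage points apart, beyond the scatter of two such steps. Among these compounds, therefore, neither change can be carried from one core to another as a fixed step, and the effect appears only in compound 3; what this does not show is why the two changes depend on each other, or how far compound 1, compound 2 and compound 4 lie from an effect at this single dose.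

The compounds shown leave open whether chlorine or a methoxy group on the aromatic ring would keep the effect of compound 3. They also leave open what a chain carbon bearing only hydrogen would do on that core.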